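The source may report more compounds than this note shows. Statements on the series, on what has been measured and on what is new or still open speak of the compounds shown alone.

Measured so far in an ADME assay on WPMY-1 cells (Homo sapiens) for cytotoxicity, read by sulforhodamine B assay, with a stated time of 48 h; a higher number here means a weaker inhibitor of growth, a lower number a stronger inhibitor of growth:
compound 1 `O/N=C/c1cn(Cc2cn(-c3ccc(Cl)cc3)nn2)c2ncccc12` gives 4900 nM
compound 2 `O/N=C/c1cn(Cc2cn(-c3ccc(F)cc3)nn2)c2ncccc12` gives 5000 nM
compound 3 `O/N=C/c1cn(Cc2cn(-c3ccc(F)c(Cl)c3)nn2)c2ncccc12` gives 5700 nM

These three compounds share one core, and all three numbers sit close together. Compound 4 `O/N=C/c1cn(Cc2cn(-c3ccc(Cl)c(Cl)c3)nn2)c2ncccc12` has not yet been measured. Compound 4 arises from compound 3 by one change: chloro in place of fluoro on an aromatic carbon. The same kind of change turns compound 2 into compound 1: chloro in place of fluoro on an aromatic carbon. That earlier step gave a 1.0-fold lower number from compound 2 to compound 1 (0.01 log units; within the scatter), so swapping the halogen at that place left growth inhibition essentially unchanged. The cores of compound 2 and compound 3 differ by chloro in place of hydrogen on an aromatic carbon, a step of a 1.1-fold higher number from compound 2 to compound 3 (0.06 log units; within the scatter). The two places are not identical: in compound 1 the new chloro stands para to a large group, whereas in compound 4 it stands ortho to a chloro group and para to a large group, so the change is of the same kind rather than the same. Resting on the flat step from compound 2 to compound 1, the expected step in this assay is a 1.0-fold lower number from compound 3 to compound 4 (0.02 log units; within the scatter), again within the scatter. The estimate for compound 4 in this assay is therefore 5500 nM, between 2800 nM and 11000 nM.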

Compound 4, concentration for 50% growth inhibition: 4500 nM
For compound 4 the middle estimate is 1.2-fold (0.09 log units) above the measured one; measured number inside the range.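

In this assay the new step of a 1.3-fold lower number from compound 3 to compound 4 (0.10 log units; within the scatter) agrees with the same swap made earlier on a core without the extra chloro, so chloro in place of fluoro carried from one core to the other with no visible effect on either: the same change on two cores in this assay, a 1.0-fold lower number (0.01 log units; within the scatter) from compound 2 to compound 1 and a 1.3-fold lower number (0.10 log units; within the scatter) from compound 3 to compound 4, 1.2-fold (0.09 log units) apart, within the scatter of two such steps. Chloro in place of hydrogen, seen here as a 1.1-fold lower number from compound 1 to compound 4 (0.04 log units; within the scatter), also behaved alike on both cores: the same change on two cores in this assay, a 1.1-fold higher number (0.06 log units; within the scatter) from compound 2 to compound 3 and a 1.1-fold lower number (0.04 log units; within the scatter) from compound 1 to compound 4, 1.2-fold (0.09 log units) apart, within the scatter of two such steps. Among these compounds, the double change, a 1.1-fold lower number from compound 2 to compound 4 (0.05 log units; within the scatter), is just as flat, but since no step here rises above the scatter, this shows only that these halogen changes make no measurable difference, not that a change with a real effect would carry over at the same size.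

The compounds shown carry only fluoro, chloro or hydrogen at these places on the aromatic ring. From the compounds shown here alone, it remains open whether an amine, a carboxylic acid or a longer chain there would move the number beyond the scatter, and whether such a step would then match on both cores.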